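Swapping the amine tail: pyrrolidine to methylpiperidine

A few compounds are considered here, and "the series" means these few. Any claim that something is new, unique, unknown or untested is made for them only; others in the source may bear on it.

Of the compounds shown here, three built on the shared core have been tested in a functional assay on U-87MG ATCC cells (Homo sapiens) for inhibition, read by MTT assay, with a stated time of 72 h; on this read-out lower numbers stand for stronger inhibition and higher numbers for weaker inhibition. Going by the values given here, compound 1 `COc1cc2c(Oc3ccc(NC(=O)c4nn(-c5ccccc5OC(F)(F)F)c(=O)cc4C)cc3F)ccnc2cc1OCCCN1CCC(C)CC1` gives 800 nM, and compound 2 `COc1cc2c(Oc3ccc(NC(=O)c4nn(-c5cccc(F)c5)c(=O)cc4C)cc3F)ccnc2cc1OCCCN1CCC(C)CC1` gives 1800 nM; the one measured step, a 2.3-fold higher number from compound 1 to compound 2 (0.35 log units; beyond the scatter), concerns the aryl group on the aromatic nitrogen. Compound 3 `COc1ccc(-n2nc(C(=O)Nc3ccc(Oc4ccnc5cc(OCCCN6CCCC6)c(OC)cc45)c(F)c3)c(C)cc2=O)cc1` gives 2960 nM in this assay, a number beyond the scatter away from compound 1, while its gap to compound 2 falls within the scatter.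

Compound 4 `COc1ccc(-n2nc(C(=O)Nc3ccc(Oc4ccnc5cc(OCCCN6CCC(C)CC6)c(OC)cc45)c(F)c3)c(C)cc2=O)cc1` differs from compound 3 in one place: 4-methylpiperidin-1-yl in place of pyrrolidin-1-yl on a saturated chain carbon, three bonds along the chain from an oxygen on an aromatic ring. Among the compounds with values here, no measured step touches this tail, so the only guide is that compound 1 and compound 2, which both carry the entering 4-methylpiperidin-1-yl group, sit at or below compound 3, yet they also differ from it elsewhere. The expected step is therefore a 1.5-fold lower number from compound 3 to compound 4 (0.17 log units; within the scatter), small and possibly within the scatter. Compound 4 is estimated at 2000 nM, with a range from 800 nM to 5000 nM.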

Compound 4, half-maximal inhibitory concentration: 2840 nM
Beside the measured number, compound 4's estimate is 1.4-fold (0.15 log units) below it, within the range that was stated.
By their numbers in this assay, from the lowest: compound 1; then compounds 2, 4 and 3 (each within the scatter of the next).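

In this assay, the step of a 1.0-fold lower number from compound 3 to compound 4 (0.02 log units; within the scatter) is within the scatter, so at this position on the saturated chain, the six-membered 4-methylpiperidin-1-yl ring and the five-membered pyrrolidin-1-yl ring cannot be told apart. With 4-methylpiperidin-1-yl held constant, 4-methoxyphenyl in place of 3-fluorophenyl on the aromatic nitrogen gives a 1.6-fold higher number from compound 2 to compound 4 (0.20 log units; within the scatter) and also stays within the scatter, whereas 4-methoxyphenyl in place of 2-(trifluoromethoxy)phenyl gives a 3.6-fold higher number from compound 1 to compound 4 (0.55 log units; beyond the scatter) and lies beyond it. Among the one-place steps shown, only those from compound 1 lie beyond the scatter, and both change the aryl group rather than the amine tail.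

Nothing available explains these numbers. On these data alone, whether a morpholine or a dimethylamino group at the end of the chain, or a longer chain, would move the number remains open.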